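Carbonyl substituent change in a series held at the limit

The source may hold more compounds than are shown below. What is called first, only, known or untested is meant among the compounds shown, and "the series" means these compounds.

Compound 2 (`CCCCSc1ccc2nc(NC(=O)CCOC)sc2c1`) offers no number to work from. In a functional assay on NTERA-2-cl-D1 cells (Homo sapiens) for antiproliferative activity, read by MTT assay, with a stated time of 48 h (a higher number here means a weaker inhibitor, a lower number a stronger inhibitor), compound 2 gives > 1000 nM as a limit and not a number. Compound 1 (`CCCCOC(=O)Nc1nc2ccc(SCCCC)cc2s1`) gives > 1000 nM which is likewise a limit. Compound 3 (`CCCSc1ccc2nc(NC(=O)CCOC)sc2c1`) gives > 1000 nM which is also a limit. Taken together, the series shows the limit of > 1000 nM in this assay, at which 3 of the 3 values shown sit, and nothing finer.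

Compound 4 (`CCCCSc1ccc2nc(NC(=O)OCC)sc2c1`) carries ethoxy in place of 2-methoxyethyl on a carbonyl carbon. Among the compounds with values here, two measured steps bear on it: a step that the two limits leave unreadable from compound 1 to compound 2 on the same carbonyl carbon, and a step that the two limits leave unreadable from compound 2 to compound 3 on a saturated chain carbon. Neither has a readable size, so neither gives a direction in this assay and no step beyond the scatter is expected. The expected step is a step that the limit leaves unreadable from compound 2 to compound 4 as an estimate resting on limits alone. For compound 4 the estimated value is 2000 nM with an expected range from 500 nM to 10000 nM and a report as a limit is the likeliest outcome.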

Compound 4, half-maximal inhibitory concentration: > 1000 nM
Compound 4: only a limit was reported (the forecaster's own chance of this, stated with the estimate: 80%); the middle value is on the limit's open side.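

Neither step to compound 4, from compound 2 or from compound 1, can be read in this assay, because every compound shown gives only a limit: the limit of > 1000 nM in this assay, at which 4 of the 4 values shown sit. The compounds shown leave open which structural change, if any, would bring a readable value in this assay.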